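Swapping a pentan-3-yl arm for 2-chlorophenyl

The source may report more compounds than this note shows. Statements on the series, on what has been measured and on what is new or still open speak of the compounds shown alone.

Among three compounds tested in a functional assay on MCF7 cells (Homo sapiens) for inhibition, read by XTT assay, with a stated time of 48 h (a higher number here means a weaker inhibitor, a lower number a stronger inhibitor), compound 3 `CCC(/C=C(\COC(=O)c1ccccc1)C(=O)c1ccc(OC)cc1)CC` gives 28000 nM, the highest of the three numbers, though compound 1 `CC(=O)OC/C(=C\c1ccccc1F)C(=O)c1ccccc1` gives 14600 nM, which lies within the scatter of it. Compound 2 `CCC(/C=C(\COC(C)=O)C(=O)c1ccc(OC)cc1)CC` gives 13700 nM. Within the data shown here, the one single-site step, a 2.0-fold higher number from compound 2 to compound 3 (0.31 log units; beyond the scatter), is a modest rise. Compound 4 `COc1ccc(C(=O)/C(=C/c2ccccc2Cl)COC(=O)c2ccccc2)cc1` differs from compound 3 by 2-chlorophenyl in place of pentan-3-yl on a double-bonded chain carbon bound to a double-bonded chain carbon. Among the measured compounds shown here, no measured step isolates this swap: compound 1 carries a 2-fluorophenyl and compound 2 a pentan-3-yl on that carbon, but they differ elsewhere as well, and their values sit within the scatter of each other. Compound 4 is therefore expected to show little movement, a 1.3-fold lower number from compound 3 to compound 4 (0.10 log units; within the scatter). The value of compound 4 in this assay is estimated at 22000 nM, within 8000 nM to 60000 nM.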

Compound 4, half-maximal inhibitory concentration: 9000 nM
For compound 4 the middle estimate is 2.4-fold (0.39 log units) above the measured one; the range from low to high includes it.
By their numbers in this assay, from the lowest: compounds 4, 2, 1 and 3 (each within the scatter of the next, the first and the last beyond it).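

Replacing pentan-3-yl with 2-chlorophenyl on a double-bonded chain carbon bound to a double-bonded chain carbon gives a 3.1-fold lower number from compound 3 to compound 4 (0.49 log units; beyond the scatter) in this assay. Among these compounds, this is the first measured single-site step at this carbon, and it shows that the number falls with an aromatic ring there while the rest of the structure stays fixed. Nothing available explains why the number falls.

The compounds shown leave open whether the ring or its chlorine carries the step: an unsubstituted phenyl or a cyclohexyl on this carbon would separate the two. On these data alone, whether the swap gives a similar step with the acetate ester of compound 2 also remains open.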